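A few compounds are considered here, and "the series" means these few. Any claim that something is new, unique, unknown or untested is made for them only; others in the source may bear on it.

All three measured compounds were tested in a functional assay (blood) for inhibition, with Homo sapiens as the target; on this read-out higher numbers stand for weaker inhibition and lower numbers for stronger inhibition:

Compound 1, `COC1(c2csc(Sc3ccc4c(c3)CC/C4=N\OCC#N)c2)CCOCC1`, gives 40 nM.
Compound 2, `COC(=O)c1cc(CO/N=C(\C)c2ccc(Sc3cc(F)cc(C4CCOCC4)c3)cc2)on1`, gives 100 nM.
Compound 3, `CO[C@]1(c2cc(F)cc(S(=O)(=O)c3ccc(/C(C)=N/OCC#N)cc3)c2)CCO[C@@H](C)C1`, gives 60 nM.

Among these three numbers, compound 2 has the highest. Its nearest neighbour is compound 3, whose number is lower, but the gap lies within the usual scatter of repeated measurements, so the two cannot be ranked against each other. Compound 1 is the furthest away, with a number lower by a margin beyond the scatter, so compound 1 inhibits more strongly than compound 2.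

Compound 4, `C/C(=N\OCC(=O)O)c1ccc(Sc2cc(F)cc(C3CCOCC3)c2)cc1`, has not yet been measured. It differs from compound 2 in one place: carboxy in place of 3-(methoxycarbonyl)-1,2-oxazol-5-yl on a saturated chain carbon bound to an oxygen on an unsaturated carbon. The group that leaves carries a five-membered aromatic ring and four hydrogen-bond acceptors; the carboxy group that enters is much smaller and brings one hydrogen-bond donor where there was none. Within the data shown here, no pair of measured compounds in this set shows such a change, so there is no measured step to lean on, and the expectation rests on the size of the change alone.

The expected step in this assay is a modest one toward weaker inhibition, a 2.5-fold higher number from compound 2 to compound 4 (0.40 log units; beyond the scatter), with a wide range because the change is large and unprecedented here. For compound 4 the estimate is 250 nM, between 60 nM and 1000 nM.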

Compound 4, half-maximal inhibitory concentration: 740 nM
Beside the measured number, compound 4's estimate is 3.0-fold (0.47 log units) below it, within the range that was stated.
By their numbers in this assay, from the lowest: compounds 1, 3 and 2 (each within the scatter of the next, the first and the last beyond it); then compound 4.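

In this assay, putting carboxy in place of 3-(methoxycarbonyl)-1,2-oxazol-5-yl on a saturated chain carbon bound to an oxygen on an unsaturated carbon gives a 7.4-fold higher number from compound 2 to compound 4 (0.87 log units; beyond the scatter). Among these compounds, this is the first step in the set where only one place changes, and it shows that the read-out responds to what sits at this position, with the rest of the molecule held the same. The exchange alters several things at once, removing a five-membered aromatic ring and adding a hydrogen-bond donor, and nothing measured here explains why the number rises.

Going by these compounds, it remains open which part of the exchange carries the step: a primary amide at this place would keep a small group without the ring, while a plain phenyl ring would keep a ring without the methoxycarbonyl group, and each would help separate these features. On these data alone, it is also open whether the same exchange would give a step of similar size on the core of compound 1, which carries a different ring system and a different chain.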